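Furan Exchanged for Methylthiophene: Cytotoxicity Expected Unchanged

The source may report more compounds than this note shows. Statements on the series, on what has been measured and on what is new or still open speak of the compounds shown alone.

Compound 1 `Cn1cc([N+](=O)[O-])cc1-c1nnc(-c2ccco2)o1` was tested in an ADME assay on Vero cells (Chlorocebus sabaeus) for cytotoxicity, read by MTT assay, with a stated time of 72 h (on this read-out higher numbers stand for weaker inhibition and lower numbers for stronger inhibition), where compound 1 gives 191000 nM. Compound 2 `O=[N+]([O-])c1c[nH]c(-c2nnc(-c3cc(-c4ccccc4)nc4ccc(Cl)cc34)o2)c1` gives 281000 nM in this assay, and compound 3 `Cn1cc([N+](=O)[O-])cc1-c1nnc(-c2ccccc2OC(F)(F)F)o1` gives 308000 nM. Compound 1 has the lowest of the three numbers, yet its gaps to compound 2 and to compound 3 both lie within the usual scatter, so the three cannot be told apart on this read-out. Compound 4 `Cc1ccc(-c2nnc(-c3cc([N+](=O)[O-])cn3C)o2)s1` has not yet been measured. It differs from compound 1 in one place: 5-methylthiophen-2-yl in place of furan-2-yl on an aromatic carbon. Among the measured compounds shown here, no measured pair shows the effect of such an exchange. The three known values sit close together, so the step expected in this assay is a 1.1-fold higher number from compound 1 to compound 4 (0.04 log units; within the scatter), with no direction beyond the scatter. Compound 4 is therefore expected to give about 210000 nM, within 100000 nM to 420000 nM.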

Compound 4, half-maximal inhibitory concentration: 98300 nM
Compound 4: middle estimate off by 2.1-fold (0.33 log units), on the high side, outside the stated range (below it).
By their numbers in this assay, from the lowest: compounds 4, 1, 2 and 3 (each within the scatter of the next, the first and the last beyond it).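

Among the compounds shown here, this is the first step that can be read at a single position: 5-methylthiophen-2-yl in place of furan-2-yl on this aromatic carbon gives a 1.9-fold lower number from compound 1 to compound 4 (0.29 log units; within the scatter) in this assay. The position therefore accepts this exchange of one five-membered aromatic ring for another, with one more heavy atom, without a step beyond the scatter. No measurement offered here explains the size of this step. The compounds shown do not separate the part played by the methyl from that of the sulfur, which a plain thiophen-2-yl group would address. As far as these compounds go, how an amine or a carboxylic acid at this position would read also remains open.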